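The compounds below may be only part of what the source reports. "The series", "measured", "known", "first", "only" and "open" are said of these compounds alone.

Three compounds were measured in an assay on membranes from frontal cortex for displacement of a labelled ligand from Adrenergic receptor alpha-1 (Rattus norvegicus), read by scintillation counting, with a stated time of 45 min; on this read-out higher numbers stand for weaker inhibition and lower numbers for stronger inhibition:

Compound 1 `CCC1(CCCCN2CCN(c3cccc(Cl)c3)CC2)C(=O)Nc2ccccc21` gives 31 nM.
Compound 2 `CCC1(CCCCN2CCN(c3ccc(Cl)cc3)CC2)C(=O)Nc2ccccc21` gives 93 nM.
Compound 3 `O=C1Nc2cc(F)ccc2C1CCCCN1CCN(c2cccc(Cl)c2)CC1` gives 12.5 nM.

Compound 1 and compound 2 share a core and differ in a single place: 4-chlorophenyl in place of 3-chlorophenyl on an amine nitrogen in a ring. This change gave a 3.0-fold higher number from compound 1 to compound 2 (0.48 log units; beyond the scatter), so the number rose and binding became weaker. Compound 3 has a different core; the difference between the two cores is not broken down here. Of the three measured compounds, compound 3 gives the lowest number, and its steps to compound 1 and to compound 2 both lie beyond the usual scatter.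

Compound 4 `O=C1Nc2cc(F)ccc2C1CCCCN1CCN(c2ccc(Cl)cc2)CC1` is not yet measured. It is built from compound 3 by the same change that turns compound 1 into compound 2: 4-chlorophenyl in place of 3-chlorophenyl on an amine nitrogen in a ring. The surroundings of the change are the same in both pairs.

The step from compound 3 to compound 4 is expected to be about a 3.0-fold higher number from compound 3 to compound 4 (0.47 log units; beyond the scatter), because the same change gave a 3.0-fold higher number from compound 1 to compound 2 (0.48 log units; beyond the scatter). On that basis compound 4 is estimated at 37 nM in this assay, with a likely range from 15 nM to 90 nM.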

Compound 4, inhibition constant: 55 nM
Beside the measured number, compound 4's estimate is 1.5-fold (0.17 log units) below it, and the stated range covers the measured number.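

In this assay, putting 4-chlorophenyl in place of 3-chlorophenyl gave a 4.4-fold higher number from compound 3 to compound 4 (0.64 log units; beyond the scatter), so the number rose and binding became weaker, the same direction as on the first core. The size of the change also carried over, with the two steps agreeing as closely as repeated measurements of this kind would allow: the same change on two cores in this assay, a 3.0-fold higher number (0.48 log units; beyond the scatter) from compound 1 to compound 2 and a 4.4-fold higher number (0.64 log units; beyond the scatter) from compound 3 to compound 4, 1.5-fold (0.17 log units) apart, within the scatter of two such steps This shows that the swap behaved alike on these two cores, but two pairs cannot show that it would do so on any other core, and they do not explain why the 4-chlorophenyl compounds give the higher numbers.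

The compounds shown leave open whether the same trend would appear with a methoxy group or a bromine in place of the chlorine on the phenyl ring. They also leave open whether it would survive a shorter or longer chain between the shared core and the ring that carries the phenyl group.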